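A few compounds are considered here, and "the series" means these few. Any claim that something is new, unique, unknown or untested is made for them only; others in the source may bear on it.

Measured so far in a functional assay on MCF7 cells (Homo sapiens) for inhibition, read by sulforhodamine B assay; a lower number here means a stronger inhibitor, a higher number a weaker inhibitor:
- Compound 1 `O=C1C=C(NC2CCCCC2)C(=O)c2c1nc1n2[C@H]2OC[C@@H](O)[C@H]2OC1`: > 8000 nM, a limit
- Compound 2 `CCOc1ccccc1NC1=CC(=O)c2nc3n(c2C1=O)[C@H]1OC[C@@H](O)[C@H]1OC3`: > 4000 nM, a limit

Neither entry is a true number. Compound 2 gives only a limit in this assay, > 4000 nM, so its exact place on the scale is not known.

The next compound, compound 3 `O=C1C=C(Nc2ccc(I)cc2)C(=O)c2c1nc1n2[C@H]2OC[C@@H](O)[C@H]2OC1`, keeps the shared core and the amine nitrogen. It carries 4-iodophenyl in place of 2-ethoxyphenyl on that nitrogen: 4-iodophenyl in place of 2-ethoxyphenyl on an amine nitrogen.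

Among the measured compounds shown here, only one measured step bears on this change, because it also swaps the group on an amine nitrogen: a step that the two limits leave unreadable from compound 1 to compound 2. Its size cannot be read, so it offers no guide to how large a new swap might be, or in which direction it might go. Both groups measured so far ended in limits, and compound 3 may well do the same.

The expected change is a number no higher from compound 2 to compound 3 (the limit leaves the size open), an estimate that carries little confidence about direction. For compound 3 the estimated value in this assay is 4000 nM, with an expected range from 1000 nM to 16000 nM.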

Compound 3, half-maximal inhibitory concentration: 2230 nM
Compound 3: middle estimate off by 1.8-fold (0.25 log units), on the high side; low and high end bracket the measured number.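

With compound 3, a group on the amine nitrogen gives a true number in this assay rather than a limit, so this position can now be placed on the scale. Compared with cyclohexyl, 4-iodophenyl gives an at least 3.5-fold lower number from compound 1 to compound 3 (0.55 log units; beyond the scatter), a real difference between the two groups, and the true gap may be larger still. Compared with 2-ethoxyphenyl, it gives an at least 1.7-fold lower number from compound 2 to compound 3 (0.25 log units; that floor lies within the scatter), so this comparison alone does not clearly separate the two phenyl groups, because its starting point is only a limit: the limit of > 4000 nM in this assay, at which 1 of the 3 values shown sits.

The compounds shown cannot tell whether the phenyl ring, the iodine or both go with the difference between compound 3 and compound 1. Going by these compounds, an unsubstituted phenyl group or a 4-chlorophenyl group on the same nitrogen would help to separate these possibilities, and how far the number can fall with other groups at this position remains open.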